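A few compounds are considered here, and "the series" means these few. Any claim that something is new, unique, unknown or untested is made for them only; others in the source may bear on it.

In a functional assay on ACHN cells (Homo sapiens) for cytotoxicity, read by sulforhodamine B assay, with a stated time of 72 h (on this read-out lower numbers stand for stronger inhibition of growth and higher numbers for weaker inhibition of growth), the measured compounds are:
Compound 1 `O=C(Nc1ccccc1O)C1CCc2ccccc2N1C(=O)c1ccccc1Cl` gives 44200 nM.
Compound 2 `CCCC(=O)N1c2ccccc2CCC1C(=O)Nc1cc(C(F)(F)F)cc(C(F)(F)F)c1` gives 13900 nM.
Compound 3 `O=C(Nc1ccc(O)cc1)C1CCc2ccccc2N1` gives > 100000 nM, which is a limit of the assay and not a number.

Compound 1 thus stands at the higher of the two numbers, with compound 2 lower by a gap beyond the usual scatter; one further value is a limit (the limit of > 100000 nM in this assay, at which 1 of the 3 values shown sits). Compound 4 `O=C(Nc1ccccc1O)C1CCc2ccccc2N1` differs from compound 1 in one place: hydrogen in place of (2-chlorophenyl)carbonyl on a nitrogen on an aromatic ring in a ring. Among the measured compounds shown here, no measured pair shows this step. Compound 3 also carries hydrogen on that ring nitrogen and gives > 100000 nM, a limit. On that basis a step toward weaker inhibition is expected for compound 4, a 2.3-fold higher number from compound 1 to compound 4 (0.35 log units; beyond the scatter). For compound 4 the estimate is 100000 nM, expected to fall between 40000 nM and 300000 nM.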

Compound 4, concentration for 50% growth inhibition: 3990 nM
Compound 4: middle estimate off by 25-fold (1.40 log units), on the high side, outside the stated range (below it).
By their numbers in this assay, from the lowest: compound 4; then compound 2; then compound 1. At a limit, above all of these: compound 3.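

In this assay, hydrogen in place of (2-chlorophenyl)carbonyl on the ring nitrogen gives an 11-fold lower number from compound 1 to compound 4 (1.04 log units; beyond the scatter), so a free ring nitrogen is compatible with stronger growth inhibition, and this acyl group is not needed for it. Hydrogen at this position does not guarantee that result, as compound 3 also carries it and stands at a limit: the limit of > 100000 nM in this assay, at which 1 of the 4 values shown sits.

As far as these compounds go, whether a small group on that nitrogen, such as methyl or acetyl, would give a number nearer that of compound 4 or that of compound 1 remains open.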